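From bis(2-hydroxyethyl)amino to hydroxyamino on a carbonyl carbon

This account rests on a few compounds, and the source may have more. Where it says the series, first, only, none or still open, it means among the compounds named here.

Measured in a functional assay on MOLT-4 cells (Homo sapiens); on this read-out lower numbers stand for stronger inhibition and higher numbers for weaker inhibition:
Compound 1 `COc1cc(NC(C)CCCNC(=O)NOCc2ccccc2)c2ncccc2c1`: 12000 nM
Compound 2 `COc1cc(NC(C)CCCNC(=O)N(CCO)CCO)c2ncccc2c1`: > 100000 nM (a limit of the assay)
Not yet measured: compound 3 `COc1cc(NC(C)CCCNC(=O)NO)c2ncccc2c1`

Compound 2 sits at a limit of this assay and has no number there, as the limit of > 100000 nM in this assay, at which 1 of the 2 values shown sits, records. Going on to compound 3 puts hydroxyamino in place of bis(2-hydroxyethyl)amino on a carbonyl carbon, and hydroxyamino in place of bis(2-hydroxyethyl)amino on a carbonyl carbon is the whole change. Going by the values given here, one measured step bears on it: an at least 8.3-fold higher number from compound 1 to compound 2 (0.92 log units; beyond the scatter) is a step at the same place and lies beyond the scatter. Compound 3 loses the same bis(2-hydroxyethyl)amino, and like compound 1 it keeps an oxygen on that nitrogen. A move back toward compound 1 at 12000 nM is therefore expected, towards lower numbers. The expected change is an at least 5.0-fold lower number from compound 2 to compound 3 (0.69 log units; beyond the scatter) in this assay. For compound 3 the estimate is 20000 nM, with an expected range of 5000 nM to 80000 nM.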

Compound 3, half-maximal inhibitory concentration: > 100000 nM
Compound 3 gave a limit, no number (the forecaster's own chance of this, stated with the estimate: 20%); at least 5.0-fold (0.69 log units) between middle value and limit.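

In this assay compound 3 gives > 100000 nM, which is a limit of the assay and not a number. With hydrogen in place of benzyl on the oxygen, the result is an at least 8.3-fold higher number from compound 1 to compound 3 (0.92 log units; beyond the scatter), so an oxygen on that nitrogen does not by itself keep a readable value, and at this position the benzyl separates compound 1 from compound 3. The step between compound 2 and compound 3 cannot be read, and hydroxyamino cannot be told apart from bis(2-hydroxyethyl)amino here, as both compounds stand at the same ceiling: the limit of > 100000 nM in this assay, at which 2 of the 3 values shown sit.

From the compounds shown here alone, how far compound 2 and compound 3 lie past that limit remains open. So does whether a methyl on that oxygen, or a benzylamino without the oxygen, would give a readable value.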